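Lengthening the side chain of compound 3

A few compounds are considered here, and "the series" means these few. Any claim that something is new, unique, unknown or untested is made for them only; others in the source may bear on it.

Of the compounds shown here, three sharing one core have been tested in a functional assay on HCT-116 cells (Homo sapiens) for cytotoxicity, read by MTT assay, with a stated time of 72 h; on this read-out higher numbers stand for weaker inhibition and lower numbers for stronger inhibition. Compound 1 `O=C1c2c[n+]([O-])c3ccccc3c2C(=O)c2c1c1ccccc1n2Cc1cn(C[C@H](O)CO)nn1` gives 400 nM, compound 2 `O=C1c2c[n+]([O-])c3ccccc3c2C(=O)c2c1c1ccccc1n2CCN1CCCC1` gives 270 nM, and compound 3 `CN1CCN(CCCn2c3c(c4ccccc42)C(=O)c2c[n+]([O-])c4ccccc4c2C3=O)CC1` gives 560 nM. Compound 3 therefore lies within the scatter of compound 1 but modestly apart from compound 2. The steps show this: a 1.4-fold higher number from compound 1 to compound 3 (0.15 log units; within the scatter), and a 2.1-fold higher number from compound 2 to compound 3 (0.32 log units; beyond the scatter). The remaining step is also small: a 1.5-fold lower number from compound 1 to compound 2 (0.17 log units; within the scatter).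

Compound 4 `CN1CCN(CCCCCCn2c3c(c4ccccc42)C(=O)c2c[n+]([O-])c4ccccc4c2C3=O)CC1` carries 3-(4-methylpiperazin-1-yl)propyl in place of 4-methylpiperazin-1-yl on a saturated chain carbon, three bonds along the chain from an aromatic nitrogen. Among the measured compounds shown here, no measured pair changes the chain length alone, so there is no direct guide. However, quite different side chains have so far shifted the number only slightly in this assay, so no step beyond the scatter is expected here. The expected change is a 1.2-fold lower number from compound 3 to compound 4 (0.09 log units; within the scatter). The estimated value for compound 4 is 450 nM, with an expected range of 180 nM to 1200 nM.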

Compound 4, half-maximal inhibitory concentration: 2900 nM
Compound 4: the middle estimate sits 6.4-fold (0.81 log units) below what was measured, outside the stated range (above it).
By their numbers in this assay, from the lowest: compounds 2, 1 and 3 (each within the scatter of the next, the first and the last beyond it); then compound 4.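

In this assay, this position proves sensitive to chain length: with the 4-methylpiperazin-1-yl end kept, 3-(4-methylpiperazin-1-yl)propyl in its place gives a 5.2-fold higher number from compound 3 to compound 4 (0.71 log units; beyond the scatter). Among the compounds shown here, this is the first step that changes chain length alone, and it is larger than any step among compound 1, compound 2 and compound 3. The longer chain also sets compound 4 well apart from the other two side chains, with an 11-fold higher number from compound 2 to compound 4 (1.03 log units; beyond the scatter) and a 7.3-fold higher number from compound 1 to compound 4 (0.86 log units; beyond the scatter).

Nothing available explains why the number rises with this change. Open, from the compounds shown here alone, is whether the rise comes gradually or abruptly, which a chain of intermediate length ending in 4-methylpiperazin-1-yl could show, and whether a long chain ending in a different amine, such as morpholine, behaves the same way.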